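Ethyl in place of hydroxy in compound 1

The source may report more compounds than this note shows. Statements on the series, on what has been measured and on what is new or still open speak of the compounds shown alone.

Measured so far in a functional assay on HaCaT cells (Homo sapiens) for antiproliferative activity, read by sulforhodamine B assay, with a stated time of 3 days; on this read-out higher numbers stand for weaker inhibition and lower numbers for stronger inhibition:
compound 1 `COC(=O)c1cc(CCc2cc(O)ccc2OC)ccc1O` gives 8700 nM
compound 2 `COC(=O)c1cc(CCc2cc(O)ccc2O)ccc1O` gives 21000 nM
compound 3 `COC(=O)c1cc(CCc2cc(OC(C)=O)ccc2OC(C)=O)ccc1O` gives 24000 nM

Of these three, compound 1 has the lowest number and so the strongest inhibition, and both other compounds lie beyond the scatter from it. Compound 4 `CCc1ccc(OC)c(CCc2ccc(O)c(C(=O)OC)c2)c1` keeps the core of compound 1 and has ethyl in place of hydroxy on an aromatic carbon, meta to a large group and para to a methoxy group ethyl in place of hydroxy on an aromatic carbon in all.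

Within the data shown here, only one measured step changes a single place. This is a 2.4-fold higher number from compound 1 to compound 2 (0.38 log units; beyond the scatter) for hydrogen in place of methyl on an oxygen on an aromatic ring, a modest step that does not touch the hydroxy leaving here. Where compound 1 has that hydroxy, an acetylated oxygen stands in the other measured ester, yet that ester differs in more than one place, so compound 3 at 24000 nM gives no clean step. Among the measured compounds shown here, no measured compound carries ethyl, so the evidence is indirect. Both changes seen on this ring stayed modest and gave higher numbers, so only a small rise in this assay is expected, probably within the scatter.

The estimated change is a 1.4-fold higher number from compound 1 to compound 4 (0.14 log units; within the scatter) and remains an expectation only. For compound 4 the expected value is 12000 nM with an estimated range from 4000 nM to 35000 nM in this assay.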

Compound 4, half-maximal inhibitory concentration: 430 nM
Compound 4: the middle estimate sits 28-fold (1.45 log units) above what was measured; the measured number lies below the stated range.
By their numbers in this assay, from the lowest: compound 4; then compound 1; then compounds 2 and 3 (each within the scatter of the next).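

In this assay, the hydroxy on this aromatic carbon, meta to a large group and para to a methoxy group, proves dispensable for inhibition: ethyl in its place gives a 20-fold lower number from compound 1 to compound 4 (1.31 log units; beyond the scatter). The earlier single-place change, a 2.4-fold higher number from compound 1 to compound 2 (0.38 log units; beyond the scatter), was only modest and altered a different oxygen substituent, so this position is the more sensitive of the two places compared so far. The exchange replaces a group counted with one hydrogen-bond donor and one acceptor by a slightly larger one counted with neither, but nothing available explains why the number falls so far.

On these data alone, it remains open whether the gain comes from the presence of ethyl or simply from the loss of hydroxy, a question that methyl, a longer chain such as propyl, or an amine at this position would help to settle. It is also unknown whether the methoxy group para to this position would matter as much with ethyl in place, or whether hydrogen in place of its methyl would have the same modest effect seen with the hydroxy present.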